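A few compounds are considered here, and "the series" means these few. Any claim that something is new, unique, unknown or untested is made for them only; others in the source may bear on it.

Working notes on the series in an assay (Rattus norvegicus) for inhibition of Fatty-acid amide hydrolase 1 (Homo sapiens); a higher number here means a weaker inhibitor, a lower number a stronger inhibitor. Compound 1 `NC(=O)c1ccc(-c2cnc(C(=O)CCCCCCc3ccccc3)o2)cc1` gives 10 nM. Compound 2 `O=C(CCCCCCc1ccccc1)c1ncc(-c2ccncn2)o1` gives 2.3 nM, and compound 3 `O=C(CCCCCCc1ccccc1)c1ncc(-c2cncnc2)o1` gives 22 nM. Compound 3 thus stands highest of the three numbers: its nearest neighbour is compound 1, through a 2.2-fold higher number from compound 1 to compound 3 (0.34 log units; beyond the scatter), and its furthest is compound 2, through a 9.6-fold higher number from compound 2 to compound 3 (0.98 log units; beyond the scatter). The next member, compound 4 `O=C(CCCCCCc1ccccc1)c1ncc(-c2nnn[nH]2)o1`, carries the change (1H-tetrazol-5-yl in place of pyrimidin-5-yl on an aromatic carbon). For the measured compounds named here, the measured steps of a 4.3-fold lower number from compound 1 to compound 2 (0.64 log units; beyond the scatter), a 2.2-fold higher number from compound 1 to compound 3 (0.34 log units; beyond the scatter) and a 9.6-fold higher number from compound 2 to compound 3 (0.98 log units; beyond the scatter) all exchange the group at this same position and bear on it, but none of them reaches a 1H-tetrazol-5-yl, so no step speaks directly for the new group. For compound 4 the expected step is a 1.1-fold higher number from compound 3 to compound 4 (0.06 log units; within the scatter) in this assay, not clearly beyond the scatter in either direction. The estimated value for compound 4 is 25 nM, with a range from 5 nM to 150 nM.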

Compound 4, inhibition constant: 63 nM
Beside the measured number, compound 4's estimate is 2.5-fold (0.40 log units) below it, within the range that was stated.
By their numbers in this assay, from the lowest: compound 2; then compound 1; then compound 3; then compound 4.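

In this assay the 1H-tetrazol-5-yl group, the only five-membered aromatic ring among the groups at this position, gives the weakest inhibitor of the four, with a 2.9-fold higher number from compound 3 to compound 4 (0.46 log units; beyond the scatter) and a 6.3-fold higher number from compound 1 to compound 4 (0.80 log units; beyond the scatter) and the largest gap as a 27-fold higher number from compound 2 to compound 4 (1.44 log units; beyond the scatter) in this series. For the compounds shown here, the position therefore spans a wider range than the earlier compounds showed, and compound 2 stays well ahead of the new group. No measurement at hand explains this order. Still open, going by these compounds, is whether a carboxylic acid at this position, or a methyl group on the tetrazole nitrogen, would fall nearer compound 2 or compound 4.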